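Triazolyl-methyl spirooxindole series: aryl change at the triazole nitrogen

A few compounds are considered here, and "the series" means these few. Any claim that something is new, unique, unknown or untested is made for them only; others in the source may bear on it.

Working notes. For the measured compounds named here, compound 3 `N#CC1=C(N)Oc2c(N)cc3nc4ccccc4nc3c2C12C(=O)N(Cc1cnnn1-c1ccccc1Br)c1ccccc12` holds the only numeric value in the set: in a functional assay on HCT-116 cells (Homo sapiens) for antiproliferative activity, read by MTT assay, with a stated time of 48 h (on this read-out higher numbers stand for weaker inhibition and lower numbers for stronger inhibition), compound 3 gives 12400 nM. Compound 1 `N#CC1=C(N)Oc2c(c3nc4ccccc4nc3c3ccccc23)C12C(=O)N(Cc1cnnn1-c1ccc(F)c(Cl)c1)c1ccccc12` returns only a limit of the assay, > 50000 nM. Compound 2 `N#CC1=C(N)Oc2c(c3nc4ccccc4nc3c3ccccc23)C12C(=O)N(Cc1cnnn1-c1cc(Cl)ccc1Cl)c1ccccc12` likewise returns only a limit, > 50000 nM. Going by the values given here, the one step between measured compounds, a step that the two limits leave unreadable from compound 1 to compound 2, cannot be read because both ends sit at the limit of > 50000 nM in this assay, at which 2 of the 3 values shown sit, so no measured step informs the change to compound 4 `Cc1ccc(-n2nncc2CN2C(=O)C3(C(C#N)=C(N)Oc4c(N)cc5nc6ccccc6nc5c43)c3ccccc32)cc1Cl`. The change is 3-chloro-4-methylphenyl in place of 2-bromophenyl on an aromatic nitrogen. With nothing to steer by, compound 4 is expected to stay within the scatter of compound 3, the estimated step being a 1.5-fold higher number from compound 3 to compound 4 (0.16 log units; within the scatter). Compound 4 is therefore estimated at 18000 nM, within 6000 nM to 50000 nM.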

Compound 4, half-maximal inhibitory concentration: > 50000 nM
Compound 4 gave a limit, no number (the forecaster's own chance of this, stated with the estimate: 30%); at least 2.7-fold (0.44 log units) between middle value and limit.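

In this assay, the aryl group on the aromatic nitrogen now gives a readable step: 3-chloro-4-methylphenyl in place of 2-bromophenyl gives an at least 4.0-fold higher number from compound 3 to compound 4 (0.60 log units; beyond the scatter). This position therefore affects the read-out on the core shared by compound 3 and compound 4. The step is one-sided, as compound 4 ends at a limit of the assay: the limit of > 50000 nM in this assay, at which 3 of the 4 values shown sit.

The step from compound 1 to compound 2 cannot be read, which leaves the effect of the chloro pattern on the aryl ring open. Also open, from the compounds shown here alone, is whether an amine or a carboxylic acid on that ring would give a number.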